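This account rests on a few compounds, and the source may have more. Where it says the series, first, only, none or still open, it means among the compounds named here.

Among the compounds with values here, in a functional assay on HCT-116 cells (Homo sapiens) for inhibition, read by MTT assay, with a stated time of 48 h (a higher number here means a weaker inhibitor, a lower number a stronger inhibitor), compound 3 `C=CC(=O)N(Cc1ccc(OC)c(O)c1)c1cc(OC)c(OC)c(OC)c1` gives 98 nM, the lowest of the three numbers measured so far. Compound 1 `C#CC(=O)N(Cc1ccc(OC)c(O)c1)c1cc(OC)c(OC)c(OC)c1` gives 310 nM and compound 2 `COc1ccc(CN(C(=O)CCl)c2cc(OC)c(OC)c(OC)c2)cc1O` gives 250 nM; both steps to compound 3 lowered the number modestly, a 3.2-fold lower number from compound 1 to compound 3 (0.50 log units; beyond the scatter) and a 2.6-fold lower number from compound 2 to compound 3 (0.41 log units; beyond the scatter). Compound 4 `COc1ccc(CN(C(=O)/C=C/CBr)c2cc(OC)c(OC)c(OC)c2)cc1O` alters the same place once more: 3-bromoprop-1-en-1-yl in place of vinyl on a carbonyl carbon. Within the data shown here, no measured step tests this particular group, so those two steps only show that swapping the group on this carbonyl carbon has moved the number by modest amounts, with vinyl the best of the three. A modest rise from compound 3 to compound 4 is therefore expected, about a 2.0-fold higher number from compound 3 to compound 4 (0.31 log units; beyond the scatter). Compound 4 is estimated at 200 nM, likely between 70 nM and 600 nM.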

Compound 4, half-maximal inhibitory concentration: 59 nM
Compound 4: middle estimate off by 3.4-fold (0.53 log units), on the high side, outside the stated range (below it).
By their numbers in this assay, from the lowest: compounds 4 and 3 (each within the scatter of the next); then compounds 2 and 1 (each within the scatter of the next).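

In this assay, the 3-bromoprop-1-en-1-yl group on this carbonyl carbon does as well as vinyl, the step staying within the scatter (a 1.7-fold lower number from compound 3 to compound 4 (0.22 log units; within the scatter)). Within the data shown here, it also stands clear of the other two groups (a 4.2-fold lower number from compound 2 to compound 4 (0.63 log units; beyond the scatter)) (a 5.3-fold lower number from compound 1 to compound 4 (0.72 log units; beyond the scatter)), so vinyl is not the only group here that outdoes chloromethyl and ethynyl. No evidence is available on why these numbers differ.

It remains open whether the bromine matters: would a plain prop-1-en-1-yl group, or a chlorine on the same chain, give a similar number?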